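Ester chain trimming: compound 2 to compound 4

The source may report more compounds than this note shows. Statements on the series, on what has been measured and on what is new or still open speak of the compounds shown alone.

In an assay on isolated protein for inhibition of Rho-associated protein kinase 2 (Homo sapiens), read by radiometric assay (on this read-out higher numbers stand for weaker inhibition and lower numbers for stronger inhibition), compound 2 `CCCCOC(=O)c1cccc(-c2cc(C(=O)Nc3ccncc3)ccc2CN)c1` gives 5.5 nM, the lowest number of the three measured, though both others lie within the scatter of it: compound 1 `NCc1ccc(C(=O)Nc2ccncc2F)cc1-c1cccc(C(=O)Oc2ccccc2)c1` gives 6.2 nM and compound 3 `COC(=O)c1cccc(-c2cc(C(=O)Nc3ccncc3F)ccc2CN)c1` gives 7.8 nM. Compound 4 `CCOC(=O)c1cccc(-c2cc(C(=O)Nc3ccncc3)ccc2CN)c1` differs from compound 2 by hydrogen in place of ethyl on a saturated chain carbon, two bonds along the chain from an oxygen next to a carbonyl group. Among the measured compounds shown here, the one measured step at the ester, a 1.3-fold higher number from compound 1 to compound 3 (0.10 log units; within the scatter), stays within the scatter despite a large change of group; compound 2 and compound 3 differ in two places, so their values only show a comparable spread. The step of a 1.1-fold higher number from compound 2 to compound 4 (0.04 log units; within the scatter) is therefore expected to stay within the scatter, with no direction favoured. Compound 4 is estimated at 6 nM, range 3 nM to 12 nM.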

Compound 4, half-maximal inhibitory concentration: < 1 nM
Compound 4: a limit, no number (the forecaster's own chance of this, stated with the estimate: 2%); middle value at least 6.0-fold (0.77 log units) away from the limit.
By their numbers in this assay, from the lowest: compounds 2, 1 and 3 (each within the scatter of the next). At a limit, below all of these: compound 4.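

In this assay the change of butyl to ethyl on the ester gives an at least 5.5-fold lower number from compound 2 to compound 4 (0.74 log units; beyond the scatter) and so shows that this position can respond to the chain it carries, which the earlier step of a 1.3-fold higher number from compound 1 to compound 3 (0.10 log units; within the scatter) at the ester oxygen did not show. The value of compound 4 is a limit of the assay, not a number: the limit of < 1 nM in this assay, at which 1 of the 4 values shown sits. The step therefore gives a minimum size only.

From the compounds shown here alone, how a propyl ester or a carboxylic acid at this position would read stays open. Compound 3 carries a methyl ester but differs from compound 4 in two places, so it does not settle the effect of a still shorter chain.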